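Acylguanidine series: chain extension from compound 3 to compound 4

A few compounds are considered here, and "the series" means these few. Any claim that something is new, unique, unknown or untested is made for them only; others in the source may bear on it.

The series shares a guanidine acylated on one nitrogen, with the other nitrogen bearing a three-carbon chain to the imidazole of histamine. In an in vitro assay on Sf9 cells for agonist activity at histamine H2 receptor (Homo sapiens), read by scintillation counting (a higher number here means that more compound is needed for the effect, a lower number that less compound is needed), compound 1 `CN(CCC(=O)/N=C(\N)NCCCc1c[nH]cn1)C(=O)c1cc2ccccc2[nH]1` gives 347 nM. Compound 2 `N/C(=N\C(=O)CNC(=O)c1cc2ccccc2[nH]1)NCCCc1c[nH]cn1` gives 955 nM in this assay. Compound 3 `CCC(=O)/N=C(\N)NCCCc1c[nH]cn1`, the smallest acyl group of the three, gives 372 nM in this assay.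

Compound 3 stands second highest of the three numbers. Its nearest neighbour is compound 1, whose number is lower by a margin within the scatter, so no order between compound 1 and compound 3 is claimed. The furthest is compound 2, whose number is higher by a margin beyond the scatter. The larger indole amide appendages of compound 1 and compound 2 thus do not bring a lower number than the plain propanoyl of compound 3.

Compound 4 `CCCC(=O)/N=C(\N)NCCCc1c[nH]cn1` is not yet measured. It differs from compound 3 as follows: methyl in place of hydrogen on a saturated chain carbon, two bonds along the chain from a carbonyl carbon. Going by the values given here, no pair of measured compounds shows this change, so no step size can be read from the data. The expectation for compound 4 is a step of a 1.2-fold lower number from compound 3 to compound 4 (0.09 log units; within the scatter) that stays within the scatter, in either direction. Compound 4 is estimated at 300 nM, with a range from 120 nM to 800 nM.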

Compound 4, half-maximal effective concentration: 141 nM
The estimate for compound 4 lay 2.1-fold (0.33 log units) above the measured number; measured number inside the range.
By their numbers in this assay, from the lowest: compound 4; then compounds 1 and 3 (each within the scatter of the next); then compound 2.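

In this assay, the acyl chain turns out to respond to a small change: methyl in place of hydrogen on a saturated chain carbon, two bonds along the chain from a carbonyl carbon, gives a 2.6-fold lower number from compound 3 to compound 4 (0.42 log units; beyond the scatter). Going by these compounds alone, this is the first step that can be read from a pair differing in one place, and it lies beyond the scatter, which the earlier compounds could not show for any single change. It rests on one pair only, propanoyl to propylcarbonyl, and nothing at hand bears on why the number falls at this position.

From the compounds shown here alone, whether a longer chain such as pentanoyl or hexanoyl continues the step, holds the number level or reverses it remains open, as does the effect of a branched chain such as isobutyryl or of a phenyl group at the end of the acyl chain. Within the data shown here, also open is whether the same methyl in place of hydrogen would give a step of similar size on the larger appendages of compound 1 and compound 2, where no such pair is available.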